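Swapping a cyclopropyl for a 4-fluorophenyl in cell toxicity

The source may report more compounds than this note shows. Statements on the series, on what has been measured and on what is new or still open speak of the compounds shown alone.

- compound 1 `Cc1cc(N2CC[C@@H](C)[C@@H](N(C)c3ncnc4[nH]ccc34)C2)n2nc(SCC3CC3)nc2n1`: 27900 nM
- compound 2 `C[C@@H]1CCN(c2cc(-c3ccccc3)nc3ncnn23)C[C@@H]1N(C)c1ncnc2[nH]ccc12`: > 100000 nM (a limit of the assay)
- compound 3 `Cc1nc2nc(SCc3ccc(Cl)cc3)nn2c(N2CC[C@@H](C)[C@@H](N(C)c3ncnc4[nH]ccc34)C2)c1C`: 99200 nM

All three results come from a toxicity assay on GES1 cells (Homo sapiens) for inhibition, read by MTT assay, with a stated time of 72 h; a higher number here means a weaker inhibitor, a lower number a stronger inhibitor. Compound 1 gives 27900 nM, the lower of the two actual numbers. Compound 3 gives 99200 nM, and this gap lies beyond the usual scatter. Compound 2 reads > 100000 nM, which is a limit and not a number.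

Compound 4 `Cc1cc(N2CC[C@@H](C)[C@@H](N(C)c3ncnc4[nH]ccc34)C2)n2nc(SCc3ccc(F)cc3)nc2n1` has not yet been measured. It keeps the core of compound 1, but 4-fluorophenyl takes the place of cyclopropyl on a saturated chain carbon bound to a sulfur: 4-fluorophenyl in place of cyclopropyl on a saturated chain carbon bound to a sulfur.

Among the measured compounds shown here, no two measured compounds differ in only one place, so this change has no direct precedent. The closest guide is compound 3, which also has a six-membered aromatic ring at that place, although it differs in other ways too, and it gives 99200 nM. On that slender basis, a higher number in this assay is expected, meaning weaker inhibition. The expected change is a 2.0-fold higher number from compound 1 to compound 4 (0.29 log units; within the scatter), which is a modest rise and may not clear the scatter by much. For compound 4 the estimate is 55000 nM, with an expected range from 18000 nM to 120000 nM.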

Compound 4, half-maximal inhibitory concentration: 12300 nM
Compound 4: the middle estimate sits 4.5-fold (0.65 log units) above what was measured; the measured number lies below the stated range.
By their numbers in this assay, from the lowest: compound 4; then compound 1; then compound 3. At a limit, above all of these: compound 2.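

In this assay, among the compounds shown here, replacing cyclopropyl with 4-fluorophenyl on a saturated chain carbon bound to a sulfur gives a 2.3-fold lower number from compound 1 to compound 4 (0.36 log units; beyond the scatter) and this is the first direct reading of a change at this place. For the compounds shown here, no earlier pair of compounds differed in only one position. In this pair, a three-membered non-aromatic ring gives way to a six-membered aromatic ring and the inhibition of these cells becomes modestly stronger, not weaker, so a lower number here points to more toxicity toward them. Nothing measured among the compounds shown accounts for this step, and its reason stays unknown.

Going by these compounds, an unsubstituted benzyl, with hydrogen in place of the fluorine, remains open at this place, so the parts played by the aromatic ring and by the fluorine in this step cannot yet be separated. A longer open chain such as n-butyl, or a chain ending in an amine, would show whether any ring at all is needed for a number in this range.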